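One chain swap, tried on a second core

A few compounds are considered here, and "the series" means these few. Any claim that something is new, unique, unknown or untested is made for them only; others in the source may bear on it.

In a functional assay on A549 cells (Homo sapiens) for antiproliferative activity, read by MTT assay, with a stated time of 72 h (on this read-out higher numbers stand for weaker inhibition and lower numbers for stronger inhibition), compound 1 `COc1cc2ncnc(N3CCc4ccccc43)c2cc1NC(=O)/C=C/C(C)C` gives 6410 nM. Compound 2 `CCC/C=C/C(=O)Nc1cc2c(N3CCc4ccccc43)ncnc2cc1OC` differs from it in one place, (propyl in place of isopropyl on a double-bonded chain carbon bound to a double-bonded chain carbon), and gives 2920 nM; that change made the step of a 2.2-fold lower number from compound 1 to compound 2 (0.34 log units; beyond the scatter). Compound 3 `COc1cc2ncnc(N3CCCc4ccccc43)c2cc1NC(=O)/C=C/C(C)C` differs from compound 1 in its core instead, (1,2,3,4-tetrahydroquinolin-1-yl in place of 2,3-dihydro-1H-indol-1-yl on an aromatic carbon). In this assay compound 3 gives 3450 nM; here the step of a 1.9-fold lower number from compound 1 to compound 3 (0.27 log units; within the scatter) stays within the scatter, so compound 1 and compound 3 cannot be told apart. Compound 4 `CCC/C=C/C(=O)Nc1cc2c(N3CCCc4ccccc43)ncnc2cc1OC` carries the same chain change on the core of compound 3: propyl in place of isopropyl on a double-bonded chain carbon bound to a double-bonded chain carbon. The place is described in identical words for both pairs, so this is the same change seen once before. For the measured compounds named here, its only measured instance is the one on the core of compound 1, a single example on a different core, so the expectation rests on that one case alone. For compound 4 the expected step in this assay is a 2.2-fold lower number from compound 3 to compound 4 (0.33 log units; beyond the scatter), similar in size to the earlier one because of a 2.2-fold lower number from compound 1 to compound 2 (0.34 log units; beyond the scatter). Compound 4 is therefore estimated at 1600 nM, likely between 800 nM and 3500 nM.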

Compound 4, half-maximal inhibitory concentration: 1800 nM
For compound 4 the middle estimate is 1.1-fold (0.05 log units) below the measured one; measured number inside the range.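

In this assay, putting propyl in place of isopropyl on the core of compound 3 gives a 1.9-fold lower number from compound 3 to compound 4 (0.28 log units; within the scatter), so that pair alone cannot be told apart, yet the step agrees with the one seen on the core of compound 1: the same change on two cores in this assay, a 2.2-fold lower number (0.34 log units; beyond the scatter) from compound 1 to compound 2 and a 1.9-fold lower number (0.28 log units; within the scatter) from compound 3 to compound 4, 1.1-fold (0.06 log units) apart, within the scatter of two such steps. The core change, read with the propyl chain in place, gives a 1.6-fold lower number from compound 2 to compound 4 (0.21 log units; within the scatter), and it agrees with the same core change read with the isopropyl chain: the same change on two cores in this assay, a 1.9-fold lower number (0.27 log units; within the scatter) from compound 1 to compound 3 and a 1.6-fold lower number (0.21 log units; within the scatter) from compound 2 to compound 4, 1.1-fold (0.06 log units) apart, within the scatter of two such steps. Together these show that, for these four compounds, the chain change and the core change each gave a similar step on either partner, but with only two cores and two chains, and with one chain step inside the scatter, they do not show a general rule or explain the numbers.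

The compounds shown leave open whether a longer chain such as butyl, or an amine, in place of propyl would fit the same picture. They also leave open whether these steps hold on any further core.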